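Sulfonate series: a diethylcarbamoyl added to compound 2

The source may hold more compounds than are shown below. What is called first, only, known or untested is meant among the compounds shown, and "the series" means these compounds.

Among the compounds with values here, compound 2 `O=C(c1ccc(Cl)c(C(F)(F)F)c1)N1CCC(n2cncc2-c2ccc(OS(=O)(=O)c3ccccc3)cc2)CC1` is the only member of the set with a number in an assay on HEK293 cells for antagonist activity at P2X purinoceptor 7 (Homo sapiens), read by fluorescence, with a stated time of 2 h; on this read-out lower numbers stand for stronger inhibition and higher numbers for weaker inhibition; there compound 2 gives 702 nM. In this assay compound 1 `O=C(Oc1ccc(-c2cncn2C2CCN(C(=O)c3ccc(Cl)c(C(F)(F)F)c3)CC2)cc1)c1cccc2cnccc12` gives > 10000 nM, a limit of the assay and not a number. Compound 3 `O=C(Oc1ccc(-c2cncn2C2CCN(C(=O)c3ccc(Cl)c(C(F)(F)F)c3)CC2)cc1)c1cccs1` likewise gives > 10000 nM, again a limit. Both sit at the limit of > 10000 nM in this assay, at which 2 of the 3 values shown sit. The measured steps of an at least 14-fold lower number from compound 1 to compound 2 (1.15 log units; beyond the scatter) and an at least 14-fold higher number from compound 2 to compound 3 (1.15 log units; beyond the scatter) exchange the whole group on the aryl oxygen; neither adds a substituent to the phenylsulfonyl ring. Compound 4 `CCN(CC)C(=O)c1cccc(S(=O)(=O)Oc2ccc(-c3cncn3C3CCN(C(=O)c4ccc(Cl)c(C(F)(F)F)c4)CC3)cc2)c1` keeps the phenylsulfonyl of compound 2 and carries diethylcarbamoyl in place of hydrogen on an aromatic carbon. Within the data shown here, no measured step bears on such a change, so no step beyond the scatter is expected in this assay. Compound 4 is estimated at 700 nM (200 nM to 3000 nM), the expected step being a 1.0-fold lower number from compound 2 to compound 4 (0.00 log units; within the scatter).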

Compound 4, half-maximal inhibitory concentration: 202 nM
Compound 4: middle estimate off by 3.5-fold (0.54 log units), on the high side; the measured number falls inside the stated range.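

The phenylsulfonyl ring of this series tolerates a substituent: in this assay diethylcarbamoyl in place of hydrogen on an aromatic carbon, meta to a large group, gives a 3.5-fold lower number from compound 2 to compound 4 (0.54 log units; beyond the scatter) with that ring kept. Within the data shown here, the earlier steps only exchanged the whole group on the aryl oxygen, so this is the only reading of a change on the ring itself. Nothing shown gives a reason for this step.

Going by these compounds, whether a carboxylic acid, an amine or a methyl ester at this place would give a similar step stays open. Also open, on these data alone, is how diethylcarbamoyl behaves elsewhere on the ring.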